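From compound 3 to compound 4: a partly unmeasured change

This account rests on a few compounds, and the source may have more. Where it says the series, first, only, none or still open, it means among the compounds named here.

Values in a functional assay (aorta) with Oryctolagus cuniculus as the target (a lower number here means tighter binding, a higher number weaker binding), for the measured compounds:
Compound 1 `COc1cc(C(C)=O)ccc1OCCCN1CCC(C(c2ccc(F)cc2)c2ccc(F)cc2)CC1` gives 1.59 nM
Compound 2 `COc1cc(C(C)=O)ccc1OCCCN1CCC(C(c2ccc(F)cc2)c2ccc(F)c(F)c2)CC1` gives 1.26 nM
Compound 3 `COC(=O)c1ccc(OCCCN2CCC(C(c3ccc(F)cc3)c3ccc(F)cc3)CC2)c(OC)c1` gives 1.26 nM

Compound 3 stands level with compound 2, and all three values lie within the scatter of one another. Compound 4 `COc1cc(OCCCN2CCC(C(c3ccc(F)cc3)c3ccc(F)cc3)CC2)ccc1C(C)=O` is still to be measured. The change is 4-acetyl-3-methoxyphenyl in place of 2-methoxy-4-(methoxycarbonyl)phenyl on an oxygen on a saturated carbon and amounts to 4-acetyl-3-methoxyphenyl in place of 2-methoxy-4-(methoxycarbonyl)phenyl on an oxygen on a saturated carbon.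

Among the measured compounds shown here, one measured step bears on part of this. Methoxy in place of methyl on a carbonyl carbon gave a 1.3-fold lower number from compound 1 to compound 3 (0.10 log units; within the scatter) and so suggests little effect when reversed. The fluoro step, a 1.3-fold lower number from compound 1 to compound 2 (0.10 log units; within the scatter), lies elsewhere in the molecule and offers no direct guide. For the measured compounds named here, no measured step covers the new placement of the groups on the phenyl. With that part unknown, the expectation leans weakly towards a higher number, and the expected step is a 2.4-fold higher number from compound 3 to compound 4 (0.38 log units; beyond the scatter) with wide uncertainty. The estimated value for compound 4 is 3 nM with an expected range from 0.8 nM to 12 nM in this assay.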

Compound 4, dissociation constant: 3.16 nM
Compound 4: the middle estimate sits 1.1-fold (0.02 log units) below what was measured, within the range that was stated.
By their numbers in this assay, from the lowest: compounds 2, 3, 1 and 4 (each within the scatter of the next, the first and the last beyond it).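

In this assay, among the compounds shown here, the exchange of 2-methoxy-4-(methoxycarbonyl)phenyl for 4-acetyl-3-methoxyphenyl on the oxygen gives a 2.5-fold higher number from compound 3 to compound 4 (0.40 log units; beyond the scatter), the only step in this set that lies beyond the scatter. The change of placement alone, 4-acetyl-3-methoxyphenyl in place of 4-acetyl-2-methoxyphenyl, gives a 2.0-fold higher number from compound 1 to compound 4 (0.30 log units; within the scatter), so the new placement on its own does not separate those two compounds. Nothing measured here explains either step.

The compounds shown leave open how much of the larger step belongs to the placement and how much to the exchange of the ester for the ketone, since the two changes are combined in it. They also leave open how a carboxylic acid or a primary amide in place of the acetyl, or a longer chain on the oxygen, would read in this assay.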